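Shortening one end of the diol series

The source may report more compounds than this note shows. Statements on the series, on what has been measured and on what is new or still open speak of the compounds shown alone.

Measured in a toxicity assay on Hepa-1c1c7 cells (Mus musculus) for inhibition; a higher number here means a weaker inhibitor, a lower number a stronger inhibitor:
- compound 1 `CCCCCC(O)C#CC#CC(O)CCC`: 19000 nM
- compound 2 `CCCCCCCCCC(O)C#CC#CC(O)CCC`: 30000 nM
- compound 3 `CCCC(O)C#CC#CC(O)C1CCCCC1`: > 50000 nM, a limit and not a number

For the measured compounds named here, compound 1 stands level with compound 2, the only other numerical value: a 1.6-fold higher number from compound 1 to compound 2 (0.20 log units; within the scatter). For compound 3 the read-out is a limit, (the limit of > 50000 nM in this assay, at which 1 of the 3 values shown sits).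

The next compound to be measured is compound 4 `CCCCCC(O)C#CC#CCO`. Its difference from compound 1 is hydrogen in place of propyl on a saturated chain carbon bound to an oxygen on a saturated carbon and a triple-bonded carbon. This puts hydrogen in place of propyl on a saturated chain carbon bound to an oxygen on a saturated carbon and a triple-bonded carbon. The same difference, cut one bond further out, reads 1-hydroxybutyl to hydroxymethyl.

Going by the values given here, only one measured step offers a guide, and it adds a butyl at a different place in the chain: a 1.6-fold higher number from compound 1 to compound 2 (0.20 log units; within the scatter). That step stays within the scatter, so it gives no reason to expect a large change, and it says little about direction. A modest step towards a higher number in this assay is expected, held with low confidence. The estimated change is a 1.5-fold higher number from compound 1 to compound 4 (0.17 log units; within the scatter). For compound 4 the estimated value is 28000 nM, with an expected range from 12000 nM to 60000 nM.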

Compound 4, half-maximal inhibitory concentration: > 50000 nM
Compound 4 was reported as a limit; the forecaster's own chance of this, stated with the estimate: 30%; at least 1.7-fold (0.25 log units) between middle value and limit.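

Taking the propyl off the saturated chain carbon bound to an oxygen on a saturated carbon and a triple-bonded carbon gives the first step in the series that clears the scatter in this assay, with an at least 2.6-fold higher number from compound 1 to compound 4 (0.42 log units; beyond the scatter). For the compounds shown here, the only earlier step, a 1.6-fold higher number from compound 1 to compound 2 (0.20 log units; within the scatter), added butyl at a different place and stays within the scatter, so this position, unlike that one, shows that the read-out in this assay can shift with a single change, here 1-hydroxybutyl to hydroxymethyl, and the shift is towards a weaker inhibitor. For compound 4 the read-out of > 50000 nM is a limit and not a number, so the step has a lower bound only, and the series now has a second compound at that ceiling: the limit of > 50000 nM in this assay, at which 2 of the 4 values shown sit.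

The compounds shown leave open how a methyl, an ethyl or a longer chain at this same carbon would read, and so whether the step follows the loss of the propyl specifically or of any chain there. Also open, as far as these compounds go, is whether an amine or a carboxylic acid on this carbon would read differently from the hydroxymethyl end of compound 4.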